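Replacing the Pyridine Arm: Compound 3 to Compound 4

This account rests on a few compounds, and the source may have more. Where it says the series, first, only, none or still open, it means among the compounds named here.

In an in vitro functional assay on HEK285-7 cells for antagonist activity at prostaglandin D2 receptor 2 (Homo sapiens), read by BRET and beta-arrestin recruitment (on this read-out higher numbers stand for larger maximal responses and lower numbers for smaller maximal responses), three compounds have been measured so far:

Compound 1 `COc1cc(-c2nc(C(c3ccc(F)cc3)c3ccc(F)cc3)sc2CC(=O)O)ccn1` gives 60%
Compound 2 `O=C(O)Cc1sc(C(c2ccc(F)cc2)c2ccc(F)cc2)nc1-c1cccc(F)c1` gives 80%
Compound 3 `Cc1cc(-c2nc(C(c3ccc(F)cc3)c3ccc(F)cc3)sc2CC(=O)O)ccn1` gives 80%

Compound 3 stands level with compound 2, the two together giving the highest numbers of the three: no change at the digits printed from compound 2 to compound 3 (within the scatter). Compound 1 sits lower, as the step of a number 20 percentage points higher from compound 1 to compound 3 (beyond the scatter) shows.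

Compound 4 `N#Cc1cc(-c2nc(C(c3ccc(F)cc3)c3ccc(F)cc3)sc2CC(=O)O)ccc1F` carries a different aromatic group at the same carbon: 3-cyano-4-fluorophenyl in place of 2-methylpyridin-4-yl on an aromatic carbon.

Among the measured compounds shown here, two measured steps bear on this exchange. Swapping a pyridine-type ring for a carbon-only six-membered ring, 3-fluorophenyl, left the number unchanged in no change at the digits printed from compound 2 to compound 3 (within the scatter), and the reverse type of swap gave a number 20 percentage points higher from compound 1 to compound 2 (beyond the scatter). Both suggest that a carbon-only ring in this place holds the maximal response at least at the level of compound 3. The added nitrile on the entering ring is without precedent among the three, so some uncertainty remains. Compound 4 is therefore expected to show no step beyond the scatter, a number 2 percentage points lower from compound 3 to compound 4 (within the scatter), with an estimated 78% (range 60% to 95%).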

Compound 4, largest response reached (reported as efficacy), in percent of the reference or control that the assay uses: 80%
For compound 4 the middle estimate is 2 percentage points below the measured one; the range from low to high includes it.
By their numbers in this assay, from the lowest: compound 1; then compounds 2, 3 and 4 (each within the scatter of the next).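

In this assay, the aromatic carbon next to the ring nitrogen accepts 3-cyano-4-fluorophenyl without a shift beyond the scatter, with no change at the digits printed from compound 3 to compound 4 (within the scatter) against the 2-methylpyridin-4-yl group and no change at the digits printed from compound 2 to compound 4 (within the scatter) against the 3-fluorophenyl group. A ring bearing a nitrile therefore sits at the same level as these two simpler rings, so three different aromatic groups now read alike at this place. The 2-methoxypyridin-4-yl group remains the one that stands apart, with a number 20 percentage points higher from compound 1 to compound 4 (beyond the scatter) as a further step beyond the scatter.

As far as these compounds go, whether an amine or a hydroxyl group on this ring would stay with the three level compounds or go with compound 1 remains open. No measurement shown here explains why these groups read alike or why compound 1 differs.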